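A fifth fluoro on the ring of compound 2

The compounds below may be only part of what the source reports. "The series", "measured", "known", "first", "only" and "open" are said of these compounds alone.

In a functional assay on Jurkat cells (Homo sapiens) (a higher number here means a weaker inhibitor, a lower number a stronger inhibitor), compound 1 `CC(C)[C@H](NC(=O)COc1cccc2ccccc12)C(=O)N[C@@H](CC(=O)O)C(=O)COc1ccc(OC(F)(F)F)cc1` gives 29100 nM and compound 2 `CC(C)[C@H](NC(=O)COc1cccc2ccccc12)C(=O)N[C@@H](CC(=O)O)C(=O)COc1c(F)c(F)cc(F)c1F` gives 4500 nM as the lower of the two numbers. Compound 3 `CC(C)[C@H](NC(=O)COc1cccc2ccccc12)C(=O)N[C@@H](CC(=O)O)C(=O)COc1c(F)c(F)c(F)c(F)c1F` differs from compound 2 by fluoro in place of hydrogen on an aromatic carbon so that 2,3,5,6-tetrafluorophenyl becomes 2,3,4,5,6-pentafluorophenyl. The new fluoro stands para to a large group. Among the compounds with values here, only one measured step bears on this change, namely a 6.5-fold lower number from compound 1 to compound 2 (0.81 log units; beyond the scatter) where 2,3,5,6-tetrafluorophenyl takes the place of 4-(trifluoromethoxy)phenyl. That step exchanged a whole group, so it is only a loose guide to a single added fluoro. A small step is therefore expected, with no firm direction and quite possibly inside the scatter. The estimated step is a 1.1-fold higher number from compound 2 to compound 3 (0.05 log units; within the scatter) and stays small. For compound 3 the expected value is 5000 nM with 1700 nM to 15000 nM as the estimated range.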

Compound 3, half-maximal inhibitory concentration: 3050 nM
For compound 3 the middle estimate is 1.6-fold (0.21 log units) above the measured one; measured number inside the range.
By their numbers in this assay, from the lowest: compounds 3 and 2 (each within the scatter of the next); then compound 1.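

Putting fluoro in place of hydrogen at this spot, para to a large group, gives a 1.5-fold lower number from compound 2 to compound 3 (0.17 log units; within the scatter) in this assay, so this single atom leaves no readable mark on the number. Set against the 4-(trifluoromethoxy)phenyl group of compound 1, the 2,3,4,5,6-pentafluorophenyl group gives a 9.5-fold lower number from compound 1 to compound 3 (0.98 log units; beyond the scatter), a step beyond the scatter, as the step to compound 2 also was. Thus the fully fluorinated ring and the 2,3,5,6-tetrafluorophenyl ring stand together on the lower side of compound 1, and no supporting measurement is available to explain either step.

On these data alone, whether a chlorine, a methoxy group or an amine at this same place would also stay within the scatter of compound 2 remains open. The compounds shown also leave open whether a ring with no fluoro at all would read closer to compound 1 or to compound 3.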